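Adding a Second Chloro to a Benzyl Purine Core

This account rests on a few compounds, and the source may have more. Where it says the series, first, only, none or still open, it means among the compounds named here.

Measured so far:
compound 1, `ClCc1ccc(Cn2cnc3c(Cl)ncnc32)cc1`: > 100000 nM
compound 2, `ClCc1cccc(Cn2cnc3ncnc(Cl)c32)c1`: 60300 nM

Both compounds were tested in a functional assay on CCRF-CEM cells (Homo sapiens) for cytotoxicity, read by sulforhodamine B assay, with a stated time of 48 h; a higher number here means that more compound is tolerated, a lower number that less compound is tolerated. Compound 1 `ClCc1ccc(Cn2cnc3c(Cl)ncnc32)cc1` gives > 100000 nM in this assay. That reading is a limit of the assay, not a number, so for compound 1 only this bound is known (the limit of > 100000 nM in this assay, at which 1 of the 2 values shown sits). Compound 2 `ClCc1cccc(Cn2cnc3ncnc(Cl)c32)c1` gives 60300 nM in this assay. For the measured compounds named here, the two structures differ in more than one place, so no single step connects them; taken together, they show that both sit at the weak, well-tolerated end of this assay.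

Compound 3 `ClCc1ccc(Cn2cnc3c(Cl)nc(Cl)nc32)cc1` has not been measured. It differs from compound 1 by chloro in place of hydrogen on an aromatic carbon. Going by the values given here, with no measured step to lean on, the expectation for this assay is a step of no size beyond the usual scatter, in either direction, with a real chance that the assay again reports only a limit. Compound 3 is therefore estimated at 90000 nM in this assay, within 35000 nM to 200000 nM. This estimate means a step of an at least 1.1-fold lower number from compound 1 to compound 3 (0.04 log units; that floor lies within the scatter).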

Compound 3, concentration lethal to 50% of the cells: 14100 nM
Compound 3: middle estimate off by 6.4-fold (0.81 log units), on the high side; the whole stated range lies above it.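

In this assay, for the compounds shown here, chloro in place of hydrogen on an aromatic carbon, between two ring nitrogen atoms, gives an at least 7.0-fold lower number from compound 1 to compound 3 (0.85 log units; beyond the scatter), the first single change in this set whose effect can be read and one that lies beyond the usual scatter. This shows that the position is not silent: one added chlorine is enough to bring compound 3 out of the weak, well-tolerated end where the two earlier compounds sat. The size of the step can be stated only as a bound, because compound 1 stands at a limit of the assay and not at a number: the limit of > 100000 nM in this assay, at which 1 of the 3 values shown sits.

The compounds shown leave open whether this shift belongs to chloro in particular or would follow from other groups at the same place, such as an amine, a methoxy group or a methyl group. They also leave open whether the chloromethyl group on the benzyl ring is needed for the shift, which a hydroxymethyl group or a plain hydrogen in its place on compound 3 could test, and whether the same chloro would shift the number on the core of compound 2.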